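The compounds below may be only part of what the source reports. "The series", "measured", "known", "first", "only" and "open" are said of these compounds alone.

Compound 1 `COc1cc(-c2nn(-c3cccc(NC(=O)c4cccc(C(F)(F)F)c4)c3)cc2-c2ccncc2)ccc1Cl` gives 1770 nM in a functional assay on MDA-MB-435 cells (Homo sapiens) for inhibition, read by sulforhodamine B assay, with a stated time of 48 h; a lower number here means a stronger inhibitor of growth, a higher number a weaker inhibitor of growth. Compound 2 `COc1cc(-c2nn(-c3cccc(NC(=O)Nc4cccc(C(F)(F)F)c4)c3)cc2-c2ccncc2)ccc1Cl` gives 2140 nM in this assay. Compound 3 `COc1cc(-c2nn(-c3cccc(NC(=O)Nc4ccc(Cl)c(C(F)(F)F)c4)c3)cc2-c2ccncc2)ccc1Cl` gives 1690 nM in this assay.

The three values sit close together: a 1.0-fold lower number from compound 1 to compound 3 (0.02 log units; within the scatter) and a 1.3-fold lower number from compound 2 to compound 3 (0.10 log units; within the scatter) are both within the scatter, as is a 1.2-fold higher number from compound 1 to compound 2 (0.08 log units; within the scatter). Compound 3 therefore stands among the others rather than apart from them.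

Compound 4 `O=C(Nc1cccc(-n2cc(-c3ccncc3)c(-c3ccc(Cl)c(O)c3)n2)c1)Nc1ccc(Cl)c(C(F)(F)F)c1` differs from compound 3 in one place: hydrogen in place of methyl on an oxygen on an aromatic ring. Within the data shown here, none of the measured steps touches this part of the molecule; all three concern the group on the carbonyl carbon or a chloro on that ring, and all three stayed within the scatter. Among the measured compounds shown here, there is thus no measured step that bears on a change at the oxygen on the aromatic ring. Going by these compounds, with no evidence in either direction, the expectation for compound 4 in this assay is a value near that of compound 3, and a 1.0-fold higher number from compound 3 to compound 4 (0.00 log units; within the scatter) is expected to be a step of no clear direction, with a wide range because the change is untested. Compound 4 is estimated at 1700 nM, between 500 nM and 6000 nM.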

Compound 4, concentration for total growth inhibition: 1770 nM
Estimate against measurement, compound 4: 1.0-fold (0.02 log units) below; low and high end bracket the measured number.
By their numbers in this assay, from the lowest: compounds 3, 1, 4 and 2 (each within the scatter of the next).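

In this assay, among these compounds, the exchange of methoxy for hydroxy on the 4-chloro-3-methoxyphenyl group gives a 1.0-fold higher number from compound 3 to compound 4 (0.02 log units; within the scatter), and this is the first measured step at this oxygen on the aromatic ring. The numbers of the two compounds cannot be told apart, so on the background of compound 3 the methyl on this oxygen makes no measurable difference to this read-out. Nothing measured alongside this result offers any explanation for it.

Going by these compounds, whether an ethoxy group or a longer chain on this oxygen, or an amine in its place, would give a number in the same range remains open. On these data alone, it is also open whether methoxy and hydroxy would stay level with the group on the carbonyl carbon of compound 1.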